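Benzylidene hydantoin acetanilides: chloro-to-hydrogen step on the anilide

A few compounds are considered here, and "the series" means these few. Any claim that something is new, unique, unknown or untested is made for them only; others in the source may bear on it.

Measured so far:
compound 1 `O=C(CN1C(=O)N/C(=C/c2ccc(Cl)cc2)C1=O)Nc1cccc(C(F)(F)F)c1`: 22900 nM
compound 2 `O=C(CN1C(=O)N/C(=C\c2ccc(Cl)cc2)C1=O)Nc1ccc(Cl)cc1`: 42700 nM
compound 3 `COc1ccc(/C=C2/NC(=O)N(CC(=O)Nc3cc(C(F)(F)F)ccc3Cl)C2=O)cc1`: < 100000 nM

In a functional assay on MDA-MB-231 cells (Homo sapiens) for inhibition, read by sulforhodamine B assay, with a stated time of 48 h (on this read-out higher numbers stand for weaker inhibition of growth and lower numbers for stronger inhibition of growth), compound 1 gives 22900 nM and compound 2 gives 42700 nM, two values that lie close to each other. For compound 3 the assay returns only a limit, < 100000 nM. That entry is one of the cases covered by the limit of < 100000 nM in this assay, at which 1 of the 3 values shown sits, so no number places compound 3 against the other two. Compound 4 `COc1ccc(/C=C2/NC(=O)N(CC(=O)Nc3cccc(C(F)(F)F)c3)C2=O)cc1` has not been measured. It differs from compound 3 by hydrogen in place of chloro on an aromatic carbon, ortho to a large group and para to the trifluoromethyl group. Going by the values given here, no step between two measured compounds connects them, so the size of this step is open. Compound 1, measured at 22900 nM, shares its anilide with compound 4 and is the nearest guide. On that basis compound 4 is expected to give about 40000 nM in this assay, within 15000 nM to 100000 nM. The expected step is a step that the limit leaves unreadable from compound 3 to compound 4, with a real chance that only a limit is returned again.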

Compound 4, concentration for total growth inhibition: 58900 nM
Beside the measured number, compound 4's estimate is 1.5-fold (0.17 log units) below it, and the stated range covers the measured number.
By their numbers in this assay, from the lowest: compounds 1, 2 and 4 (each within the scatter of the next, the first and the last beyond it).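

In this assay, going by these compounds alone, the anilide bearing only the trifluoromethyl group now has a first step that can be read: methoxy in place of chloro on an aromatic carbon gives a 2.6-fold higher number from compound 1 to compound 4 (0.41 log units; beyond the scatter), so this exchange carries a modest cost with the rest of the molecule held fixed. Compound 3 stands at < 100000 nM, which is a limit and not a number. The step for hydrogen in place of chloro on the anilide therefore still cannot be read, because the value at one end of it is only a limit: the limit of < 100000 nM in this assay, at which 1 of the 4 values shown sits.

On these data alone, the size and direction of the chloro-to-hydrogen step remain open. As far as these compounds go, it is also open how an amine or a carboxylic acid in the place of the methoxy would compare with compound 1 and compound 4.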